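From Benzyl to Indanyl on the Amine of Compound 1

The source may hold more compounds than are shown below. What is called first, only, known or untested is meant among the compounds shown, and "the series" means these compounds.

Compound 1 `c1ccc(CNCC2CCN(CCCc3c[nH]c4ccc(-n5cnnc5)cc34)CC2)cc1` is the reference. Going by the values given here, in an assay on CHO cells for displacement of a labelled ligand from 5-hydroxytryptamine receptor 1B (Homo sapiens) (a higher number here means a weaker inhibitor, a lower number a stronger inhibitor), compound 1 gives 28 nM, the second highest of the three numbers measured so far. Compound 2 `CC(=O)Nc1ccc([C@H](C)NCC2CCN(CCCc3c[nH]c4ccc(-n5cnnc5)cc34)CC2)cc1` gives 9.3 nM, and compound 3 `c1cc(CNC2CCN(CCCc3c[nH]c4ccc(-n5cnnc5)cc34)CC2)co1` gives 78 nM. The new compound 4 `c1ccc2c(c1)CCC2NCC1CCN(CCCc2c[nH]c3ccc(-n4cnnc4)cc23)CC1` differs from compound 1 in one place: 2,3-dihydro-1H-inden-1-yl in place of benzyl on an amine nitrogen. Among the compounds with values here, two measured steps bear on this. Moving to 1-(4-acetamidophenyl)ethyl on the same amine nitrogen gave a 3.0-fold lower number from compound 1 to compound 2 (0.48 log units; beyond the scatter), whereas exchanging the benzylamino arm for a furan arm gave a 2.8-fold higher number from compound 1 to compound 3 (0.44 log units; beyond the scatter). The entering group keeps a six-membered aromatic ring and adds a five-membered non-aromatic ring, so a modest step is expected, nearer in direction to a 3.0-fold lower number from compound 1 to compound 2 (0.48 log units; beyond the scatter) than to a 2.8-fold higher number from compound 1 to compound 3 (0.44 log units; beyond the scatter). The expected step is a 1.4-fold lower number from compound 1 to compound 4 (0.15 log units; within the scatter), and compound 4 is estimated at 20 nM, between 7 nM and 60 nM.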

Compound 4, half-maximal inhibitory concentration: 25 nM
Estimate against measurement, compound 4: 1.3-fold (0.10 log units) below; the range from low to high includes it.
By their numbers in this assay, from the lowest: compound 2; then compounds 4 and 1 (each within the scatter of the next); then compound 3.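

On the amine nitrogen, 2,3-dihydro-1H-inden-1-yl in place of benzyl leaves the number in this assay within the scatter, with a 1.1-fold lower number from compound 1 to compound 4 (0.05 log units; within the scatter), so this position accepts the added five-membered non-aromatic ring. The change does not match the acetamidophenyl compound, with a 2.7-fold higher number from compound 2 to compound 4 (0.43 log units; beyond the scatter), and it stays clear of the furan compound, with a 3.1-fold lower number from compound 3 to compound 4 (0.49 log units; beyond the scatter). No measurement shown here explains these steps.

From the compounds shown here alone, it remains open whether the lower number of compound 2 goes with its acetamido group or its methyl branch, which a plain 1-phenylethyl group on this amine would separate. Going by these compounds, whether an acetamido group on the 2,3-dihydro-1H-inden-1-yl ring would act alike is also open.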